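A smaller aryl group on the shared core

A few compounds are considered here, and "the series" means these few. Any claim that something is new, unique, unknown or untested is made for them only; others in the source may bear on it.

In a functional assay on MCF7 cells (Homo sapiens) for antiproliferative activity, read by MTT assay, with a stated time of 72 h (a higher number here means a weaker inhibitor, a lower number a stronger inhibitor), compound 1 `CCCNC(=O)c1cc(Oc2ccc(NC(=O)c3nn(-c4ccc(C)cc4)c(=O)cc3C)cc2F)ccn1` gives 34600 nM, and compound 2 `CCCNC(=O)c1cc(Oc2ccc(NC(=O)c3nn(-c4ccccc4OC(F)(F)F)c(=O)cc3C)cc2F)ccn1` gives 7420 nM, the lower of the two numbers. Among the measured compounds shown here, the single measured step between them is a 4.7-fold lower number from compound 1 to compound 2 (0.67 log units; beyond the scatter), with 2-(trifluoromethoxy)phenyl in place of 4-methylphenyl on an aromatic nitrogen. Compound 3 `CCCNC(=O)c1cc(Oc2ccc(NC(=O)c3nn(-c4cccc(F)c4)c(=O)cc3C)cc2F)ccn1` changes the same place, with 3-fluorophenyl in place of 2-(trifluoromethoxy)phenyl on an aromatic nitrogen. For the measured compounds named here, no measured compound carries 3-fluorophenyl, so the modest step of a 4.7-fold lower number from compound 1 to compound 2 (0.67 log units; beyond the scatter) is the only guide, and it is a weak one. A shift toward a higher number in this assay is expected, smaller than that measured step and leaving compound 3 between the two known values. The expected change is a 2.2-fold higher number from compound 2 to compound 3 (0.33 log units; beyond the scatter). For compound 3 the estimate is 16000 nM, with an expected range of 5500 nM to 42000 nM.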

Compound 3, half-maximal inhibitory concentration: 13300 nM
Estimate against measurement, compound 3: 1.2-fold (0.08 log units) above; the range from low to high includes it.
By their numbers in this assay, from the lowest: compounds 2 and 3 (each within the scatter of the next); then compound 1.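

Replacing 2-(trifluoromethoxy)phenyl with the smaller 3-fluorophenyl on the aromatic nitrogen gives a 1.8-fold higher number from compound 2 to compound 3 (0.25 log units; within the scatter) in this assay, so the two groups cannot be told apart here. The comparison with 4-methylphenyl gives a 2.6-fold lower number from compound 1 to compound 3 (0.42 log units; beyond the scatter), which shows that the lower number seen against compound 1 does not depend on 2-(trifluoromethoxy)phenyl alone, as 3-fluorophenyl also gives it. No evidence is available to explain these differences.

Since the three aryl groups differ in both substituent and its place on the ring, the compounds shown cannot separate the effect of the substituent from that of its place. As far as these compounds go, it also remains open how unsubstituted phenyl, 2-fluorophenyl, 4-fluorophenyl, or a phenyl carrying an amine or a carboxylic acid would behave at this position.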